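The compounds below may be only part of what the source reports. "The series", "measured", "known", "first", "only" and "open" are said of these compounds alone.

Measured so far in an ADME assay on microsomes from liver (Homo sapiens) for metabolic stability, read by LC-MS, using NADPH, with a stated time of 60 min, tested at 1 uM; on this read-out lower numbers stand for slow clearance and higher numbers for fast clearance:
- compound 1 `CNC(=O)c1cc(S(=O)(=O)N2CCS[C@H]2C(=O)O[C@@H](Cc2c(Cl)c[n+]([O-])cc2Cl)c2ccc(OC(F)F)c(OCC3CC3)c2)cn1C`: 202 mL.min-1.g-1
- compound 2 `Cn1cnc(S(=O)(=O)N2CCS[C@H]2C(=O)O[C@@H](Cc2c(Cl)c[n+]([O-])cc2Cl)c2ccc(OC(F)F)c(OCC3CC3)c2)c1`: 281 mL.min-1.g-1

For the measured compounds named here, compound 2 stands alongside compound 1 in this short set; the two values are separated only by a 1.4-fold higher number from compound 1 to compound 2 (0.14 log units; within the scatter), which is the single step the data hold and which swapped one group for another on the sulfonyl sulfur. Compound 3 `COc1ccc(S(=O)(=O)N2CCS[C@H]2C(=O)O[C@@H](Cc2c(Cl)c[n+]([O-])cc2Cl)c2ccc(OC(F)F)c(OCC3CC3)c2)cc1OC` carries 3,4-dimethoxyphenyl in place of 1-methyl-1H-imidazol-4-yl on a sulfonyl sulfur. Going by the values given here, no measured step bears directly on this change. Among the compounds with values here, the one step available, on the same sulfonyl sulfur, stayed within the scatter, and both measured compounds sit in the same region of this assay. The expectation for compound 3 is therefore no step beyond the scatter. Within the data shown here, the change has no precedent in this set; the range is set wide. Compound 3 is estimated at 270 mL.min-1.g-1 (range 120 mL.min-1.g-1 to 600 mL.min-1.g-1), an expected step of a 1.0-fold lower number from compound 2 to compound 3 (0.02 log units; within the scatter).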

Compound 3, intrinsic clearance in microsomes: 200 mL.min-1.g-1
Beside the measured number, compound 3's estimate is 1.4-fold (0.13 log units) above it; measured number inside the range.
By their numbers in this assay, from the lowest: compounds 3, 1 and 2 (each within the scatter of the next).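

In this assay, 3,4-dimethoxyphenyl in place of 1-methyl-1H-imidazol-4-yl on the sulfonyl sulfur gives a 1.4-fold lower number from compound 2 to compound 3 (0.15 log units; within the scatter), and the comparison with the group of compound 1 gives a 1.0-fold lower number from compound 1 to compound 3 (0.00 log units; within the scatter). The earlier compounds shown here carried only five-membered aromatic rings with hetero atoms at this position, so the series now shows that a six-membered aromatic ring of carbon only also leaves the read-out within the scatter of both. No available measurement accounts for this flat result. Still open, from the compounds shown here alone, is whether a group without an aromatic ring on the sulfonyl sulfur, such as a short alkyl chain or an amine, would give a step beyond the scatter. The compounds shown also leave open whether any change elsewhere in the shared core would do so.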